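Chloro in place of the amine on a shared quinoline-type core

The source may hold more compounds than are shown below. What is called first, only, known or untested is meant among the compounds shown, and "the series" means these compounds.

This account follows three measured compounds and a fourth whose number is still to come. Compound 1 `CN(C)CCCNc1ccnc2cc(OCc3ccc(F)cc3)ccc12` was tested in a functional assay on RKO cells (Homo sapiens) for cytotoxicity, read by MTT assay, with a stated time of 48 h (on this read-out lower numbers stand for stronger inhibition and higher numbers for weaker inhibition), where compound 1 gives 1230 nM. Compound 2 `Fc1ccc(COc2ccc3c(Cl)ccnc3c2)cc1` differs from compound 1 by chloro in place of (3-(dimethylamino)propyl)amino on an aromatic carbon, and in this assay compound 2 gives 1980 nM, a step of a 1.6-fold higher number from compound 1 to compound 2 (0.21 log units; within the scatter). Compound 3 `C=CCOc1ccc2c(NCCCN(C)C)ccnc2c1` keeps the (3-(dimethylamino)propyl)amino group of compound 1 but changes the other side: the difference between the two cores is vinyl in place of 4-fluorophenyl on a saturated chain carbon bound to an oxygen on an aromatic ring. In this assay compound 3 gives 3560 nM, a step of a 2.9-fold higher number from compound 1 to compound 3 (0.46 log units; beyond the scatter).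

Compound 4 `C=CCOc1ccc2c(Cl)ccnc2c1` is built from compound 3 by chloro in place of (3-(dimethylamino)propyl)amino on an aromatic carbon. For the measured compounds named here, this is the same change as the one made from compound 1 to compound 2, on the same place, and that earlier step of a 1.6-fold higher number from compound 1 to compound 2 (0.21 log units; within the scatter) lay within the scatter. On the core of compound 3, the change is therefore expected to give a step of about a 1.5-fold higher number from compound 3 to compound 4 (0.19 log units; within the scatter), a number in the same direction and of the same order as the earlier one, because that earlier step measured a 1.6-fold higher number from compound 1 to compound 2 (0.21 log units; within the scatter). On that basis compound 4 is estimated to give 5500 nM in this assay, with the expected range running from 2500 nM to 12000 nM. What compound 4 actually gives in this assay is told next.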

Compound 4, half-maximal inhibitory concentration: 2460 nM
The estimate for compound 4 lay 2.2-fold (0.35 log units) above the measured number; measured number outside the range, below it.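

In this assay, chloro in place of (3-(dimethylamino)propyl)amino on the second core gives a step of a 1.4-fold lower number from compound 3 to compound 4 (0.16 log units; within the scatter), and this step cannot be told apart from the one on the first core: the same change on two cores in this assay, a 1.6-fold higher number (0.21 log units; within the scatter) from compound 1 to compound 2 and a 1.4-fold lower number (0.16 log units; within the scatter) from compound 3 to compound 4, 2.3-fold (0.37 log units) apart, within the scatter of two such steps. For these two pairs, then, the change carries from one core to the other as a step that stays within the scatter, and the opposite directions of the two printed steps are no evidence of a real reversal. For the compounds shown here, this does not show that the change would stay this small on other cores or in other cell lines, or that the (3-(dimethylamino)propyl)amino group has no bearing on cytotoxicity in general, since the comparison rests on only two pairs in one assay.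

The compounds shown leave open how other groups would behave on that aromatic carbon opposite the ring nitrogen, such as a plain amine, a shorter (2-(dimethylamino)ethyl)amino chain or a morpholine ring. They also leave open whether the change would stay as small on a core carrying a simple methoxy group or an unsubstituted benzyl ether on the other side.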